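A few compounds are considered here, and "the series" means these few. Any claim that something is new, unique, unknown or untested is made for them only; others in the source may bear on it.

In a functional assay on DU-145 cells (Homo sapiens) for inhibition, read by MTT assay, with a stated time of 72 h (on this read-out lower numbers stand for stronger inhibition and higher numbers for weaker inhibition), compound 1 `O=C1C=C(N2CCN(c3ccc(F)cc3)CC2)C(=O)c2ccccc21` gives 11700 nM. Compound 2 `O=C1C=C(N2CCN(c3cccc(Cl)c3)CC2)C(=O)c2ccccc21` gives 8300 nM, so these two compounds stand level within the scatter. Going by the values given here, that comparison is the only measured step here: a 1.4-fold lower number from compound 1 to compound 2 (0.15 log units; within the scatter). It concerns the group on the ring amine nitrogen, not the core. Compound 3 `O=C1C=C(N2CCN(c3ccc(F)cc3)CC2)C(=O)c2c(O)cccc21` keeps the 4-fluorophenyl group of compound 1 and changes the core instead: hydroxy in place of hydrogen on an aromatic carbon. Among the compounds with values here, no measured step tests this change, so the data give only a weak guide to its size or direction. The expected step is small, with a slight lean towards a lower number and no clear move beyond the scatter: a 1.7-fold lower number from compound 1 to compound 3 (0.22 log units; within the scatter). For compound 3 the estimated value is 7000 nM, with an expected range from 2000 nM to 20000 nM.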

Compound 3, half-maximal inhibitory concentration: 8400 nM
Beside the measured number, compound 3's estimate is 1.2-fold (0.08 log units) below it; measured number inside the range.
By their numbers in this assay, from the lowest: compounds 2, 3 and 1 (each within the scatter of the next).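

Going by these compounds alone, the earlier pair varied only the group on the ring amine nitrogen, so this is the first measured change to the shared core. In this assay, hydroxy in place of hydrogen on an aromatic carbon of the carbon-only ring of the fused system gives a 1.4-fold lower number from compound 1 to compound 3 (0.14 log units; within the scatter), so at this position the change leaves compound 3 level with compound 1 and shows no effect that can be told from the scatter. No supporting data are available to explain this result.

From the compounds shown here alone, it remains open whether a methoxy group or an amine at this same place, or on another carbon of that ring, would move the number beyond the scatter. Also open, going by these compounds, is whether hydroxy would behave the same way alongside the 3-chlorophenyl group of compound 2.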